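The source may report more compounds than this note shows. Statements on the series, on what has been measured and on what is new or still open speak of the compounds shown alone.

Two glucose-derived compounds have so far been measured in an assay on isolated protein (Sus scrofa) for inhibition of glycogen phosphorylase, brain form (Homo sapiens); a higher number here means a weaker inhibitor, a lower number a stronger inhibitor. Compound 1 `[N-]=[N+]=NC[C@H]1O[C@H](CO)[C@@H](O)[C@H](O)[C@H]1O` carries an azidomethyl group on a saturated ring carbon of the shared core; in this assay compound 1 gives 25100000 nM. Compound 2 `NC(=O)CS[C@H]1O[C@H](CO)[C@@H](O)[C@H](O)[C@H]1O` has a (carbamoylmethyl)sulfanyl group at that position instead, and in this assay compound 2 gives 20000000 nM. Among the measured compounds shown here, the single step between them, a 1.3-fold lower number from compound 1 to compound 2 (0.10 log units; within the scatter), leaves the two numbers indistinguishable, so compound 2 merely holds the lower of two numbers, with compound 1 within the scatter beside it.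

Compound 3 `NC(=O)N[C@H]1O[C@H](CO)[C@@H](O)[C@H](O)[C@H]1O` is the next member: ureido in place of (carbamoylmethyl)sulfanyl on a saturated ring carbon. For the measured compounds named here, no measured step touches a ureido group, and the only step available, from an azidomethyl to a (carbamoylmethyl)sulfanyl substituent, was within the scatter, so the data give no firm direction. Still, both measured numbers sit very high, and a compact ureido group at the same saturated ring carbon is expected to move the number downward, by roughly a 10-fold lower number from compound 2 to compound 3 (1.00 log units; beyond the scatter). Compound 3 is therefore estimated at 2000000 nM in this assay, within a range from 300000 nM to 15000000 nM.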

Compound 3, inhibition constant: 126000 nM
Compound 3: the middle estimate sits 16-fold (1.20 log units) above what was measured; measured number below the stated range.
By their numbers in this assay, from the lowest: compound 3; then compounds 2 and 1 (each within the scatter of the next).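

The earlier pair suggested that this saturated ring carbon, next to the ring oxygen, might tolerate a change of substituent without any effect, but ureido in this assay gives a 160-fold lower number from compound 2 to compound 3 (2.20 log units; beyond the scatter) and a 200-fold lower number from compound 1 to compound 3 (2.30 log units; beyond the scatter) and so shows that the number does depend on what this position carries. Both of these steps are large and beyond the scatter, and they set compound 3 clearly apart from two compounds that cannot be told apart from each other. In the change from compound 2 to compound 3, both groups are free of rings and net charge and each has one double bond, so what differs is the loss of sulfur, the gain of a second nitrogen and the tally of hydrogen-bond donors and acceptors, yet no supporting measurement says which of these differences matters.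

The compounds shown leave open whether the whole ureido group is needed, since a simple amine or an acetamido group on the same carbon would test its parts. They also leave open whether this position accepts anything larger, such as a methylureido group or a longer chain on the far nitrogen.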